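The compounds below may be only part of what the source reports. "The series", "measured", "known", "first", "only" and "open" are said of these compounds alone.

Compound 1, `O=C([C@@H]1CCCN(S(=O)(=O)c2ccc(S(=O)(=O)N3CC[C@@H](O)C3)cc2)C1)N1CCC(F)(F)CC1`, gives 330 nM.
Compound 2, `CCN(CC)S(=O)(=O)c1ccc(S(=O)(=O)N2CCC[C@@H](C(=O)N3CCC(OC)CC3)C2)cc1`, gives 1420 nM.

Both compounds were tested in a functional assay on BXPC-3 cells (Homo sapiens) for inhibition, read by MTT assay, with a stated time of 7 days; on this read-out higher numbers stand for weaker inhibition and lower numbers for stronger inhibition. Of the two numbers, compound 1 has the lower one, and compound 2 stands a good way above it, a gap that lies beyond the usual scatter of repeated measurements. Going by the values given here, these two structures differ in more than one place, so no single step between them can be read off; their two values only show that one is clearly weaker than the other.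

Compound 3, `CCN(CC)C(=O)c1ccc(S(=O)(=O)N2CCC[C@@H](C(=O)N3CCC(F)(F)CC3)C2)cc1`, has not yet been measured. It differs from compound 1 in one place: diethylcarbamoyl in place of (3-hydroxypyrrolidin-1-yl)sulfonyl on an aromatic carbon. A diethyl group on the aromatic ring is also a feature of compound 2, although there it sits on a sulfonyl rather than a carbonyl, and compound 2 carries a different group on the other end of the molecule as well.

Because compound 2 gives 1420 nM with a diethyl-bearing group on that ring, compound 3 is expected to lose some potency against compound 1, a step of a 2.1-fold higher number from compound 1 to compound 3 (0.33 log units; beyond the scatter). The estimated value for compound 3 is 700 nM, with a plausible range from 250 nM to 2000 nM.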

Compound 3, half-maximal inhibitory concentration: 240 nM
Compound 3: middle estimate off by 2.9-fold (0.46 log units), on the high side, and the stated range ends above it.
By their numbers in this assay, from the lowest: compounds 3 and 1 (each within the scatter of the next); then compound 2.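

In this assay, placing diethylcarbamoyl instead of (3-hydroxypyrrolidin-1-yl)sulfonyl on this aromatic carbon, para to a large group, gives a 1.4-fold lower number from compound 1 to compound 3 (0.14 log units; within the scatter), so the two compounds cannot be told apart. Going by these compounds alone, this is the first single-place comparison at this position, and it shows that the position accepts two quite different groups with no clear change in the value: the group that enters has no ring, no hydrogen-bond donor and no defined stereocentre, and it replaces a sulfonyl link with a carbonyl, so none of these features of the group that leaves is required to hold the value at this level in this pair. No measurement here explains why the value holds across this change.

As far as these compounds go, it remains open how far this tolerance extends, for example to a carboxylic acid, a primary amine or a much longer alkyl chain on the same aromatic carbon. From the compounds shown here alone, it is also open whether the same swap would give a similar result with a group other than the 4,4-difluoropiperidine amide at the other end of the molecule.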